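Cytotoxicity in the Series: Methylsulfonyl Analogue Expected Inactive

The compounds below may be only part of what the source reports. "The series", "measured", "known", "first", "only" and "open" are said of these compounds alone.

Compound 3 `CCOC(=O)CCCCCOc1cccc(CN(C(=O)c2ccc(-c3cccc(F)c3)cc2)C(C)C)c1` is the reference point. In an ADME assay on BJ cells (Homo sapiens) for cytotoxicity, read by CellTiter-Glo and resazurin assay, with a stated time of 72 h (a lower number here means that less compound is needed, a higher number that more compound is needed for the effect), compound 3 gives only a limit, > 26000 nM. Compound 1 `CCOC(=O)CCCCCOc1cccc(CN(C(=O)c2ccc(-c3ccoc3)cc2)C(C)C)c1` likewise gives only a limit in this assay, > 26000 nM. Compound 2 `CCOC(=O)CCCCCOc1cccc(CN(C(=O)c2ccc(-c3cccc(OCc4ccccc4)c3)cc2)C(C)C)c1` also gives only a limit in this assay, > 26000 nM. The step that the two limits leave unreadable from compound 1 to compound 3 and the step that the two limits leave unreadable from compound 2 to compound 3 cannot be sized because the limit of > 26000 nM in this assay, at which 3 of the 3 values shown sit, holds every value shown.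

Compound 4 `CCOC(=O)CCCCCOc1cccc(CN(C(=O)c2ccc(-c3cccc(S(C)(=O)=O)c3)cc2)C(C)C)c1` differs from compound 3 by methylsulfonyl in place of fluoro on an aromatic carbon. Going by the values given here, no measured step in this assay reads a size; all three values are limits, and the evidence shows only that three different groups on that aromatic carbon each leave the read-out at the limit. The step that the limit leaves unreadable from compound 3 to compound 4 is therefore expected to be none beyond the scatter, most likely ending again at the limit. Compound 4 is estimated at 40000 nM in this assay, with a range from 20000 nM to 120000 nM.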

Compound 4, half-maximal effective concentration: > 26000 nM
Compound 4 was reported as a limit; the forecaster's own chance of this, stated with the estimate: 85%; the middle value lies beyond the limit too.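

No step from compound 1, compound 2 or compound 3 to compound 4 can be read in this assay, because all four values are limits: the limit of > 26000 nM in this assay, at which 4 of the 4 values shown sit.

The compounds shown leave open how these four compare, and whether any group on that aromatic carbon gives a readable value.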